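The source may report more compounds than this note shows. Statements on the series, on what has been measured and on what is new or still open speak of the compounds shown alone.

Measured compounds:
- compound 1, `c1ccc(-c2cnccn2)c(OCC2=NCCN2)c1`: 46%
- compound 2, `c1coc(-c2ccccc2OCC2=NCCN2)c1`: 110%

Among the measured compounds shown here, in a functional assay for activation of Alpha-1B adrenergic receptor (Homo sapiens), read by calcium flux (a lower number here means a smaller maximal response, a higher number a larger maximal response), compound 1 gives 46%, the lowest of the two numbers so far; its nearest neighbour is compound 2, which gives 110%. For the measured compounds named here, the one measured step, a number 64 percentage points higher from compound 1 to compound 2 (beyond the scatter), comes from furan-2-yl in place of pyrazin-2-yl on an aromatic carbon.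

Compound 3, `c1ccc(-c2nccs2)c(OCC2=NCCN2)c1`, has not been measured in this assay. It differs from compound 1 by 1,3-thiazol-2-yl in place of pyrazin-2-yl on an aromatic carbon. Going by the values given here, the only step that bears on this change is a number 64 percentage points higher from compound 1 to compound 2 (beyond the scatter), in which one six-membered aromatic ring with 2 hetero atoms was likewise exchanged for a five-membered aromatic ring. Among the compounds with values here, with only that single step to go on, the step expected for compound 3 is estimated as a number 34 percentage points higher from compound 1 to compound 3 (beyond the scatter). That expected rise is smaller than the measured one, a number 64 percentage points higher from compound 1 to compound 2 (beyond the scatter). The estimate for compound 3 in this assay is therefore 80%, with a range from 45% to 115%.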

Compound 3, largest response reached (reported as maximum), in percent of the reference or control that the assay uses: 100%
Compound 3: the middle estimate sits 20 percentage points below what was measured, within the range that was stated.
By their numbers in this assay, from the lowest: compound 1; then compounds 3 and 2 (each within the scatter of the next).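

In this assay, 1,3-thiazol-2-yl on this aromatic carbon also gives a large rise over pyrazin-2-yl, a number 54 percentage points higher from compound 1 to compound 3 (beyond the scatter), so the rise is not tied to furan-2-yl alone. The exchange between the two five-membered aromatic rings gives a number 10 percentage points lower from compound 2 to compound 3 (within the scatter), which leaves furan-2-yl and 1,3-thiazol-2-yl indistinguishable here despite the sulfur that enters with the latter. Nothing available explains why compound 1 stands apart from compound 2 and compound 3.

Pyrazin-2-yl is the only six-membered aromatic ring shown, so the compounds leave open whether the lower response belongs to six-membered aromatic rings in general or to this ring alone. Going by these compounds, how a plain phenyl or a pyridin-2-yl group would behave on this carbon remains open.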